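The source may hold more compounds than are shown below. What is called first, only, known or untested is meant among the compounds shown, and "the series" means these compounds.

In a functional assay on U2OS cells (Homo sapiens) for cytotoxicity, read by MTT assay, with a stated time of 48 h (on this read-out lower numbers stand for stronger inhibition and higher numbers for weaker inhibition), three compounds have been measured so far:

Compound 1 `Fc1cccc(-c2nc(Nc3ccccc3)c3cc(F)ccc3n2)c1` gives 47600 nM.
Compound 2 `Fc1cccc(Nc2nc(-c3cccc(F)c3)nc3ccc(F)cc23)c1` gives 49600 nM.
Compound 3 `Fc1cccc(-c2nc(Nc3ccccc3Br)c3cc(F)ccc3n2)c1` gives > 50000 nM, which is a limit of the assay and not a number.

Compound 1 and compound 2 sit within the scatter of each other: a 1.0-fold higher number from compound 1 to compound 2 (0.02 log units; within the scatter). From compound 1 to compound 3 the picture is the same in kind, an at least 1.0-fold higher number from compound 1 to compound 3 (0.02 log units; that floor lies within the scatter), since compound 3 only reached (the limit of > 50000 nM in this assay, at which 1 of the 3 values shown sits). Compound 3 therefore stands at the edge of what this assay can report, with no number of its own.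

Compound 4 `Oc1cccc(Nc2nc(-c3cccc(F)c3)nc3ccc(F)cc23)c1` differs from compound 3 in one place: 3-hydroxyphenyl in place of 2-bromophenyl on a nitrogen on an aromatic ring. For the measured compounds named here, the one measured step that also swaps the group on that nitrogen is a number no lower from compound 2 to compound 3 (the limit leaves the size open), whose size cannot be read. All three measured compounds cluster near the limit, so compound 4 is expected to show no step beyond the scatter, a number no higher from compound 3 to compound 4 (the limit leaves the size open). The estimate for compound 4 is 50000 nM, with a range from 20000 nM to 120000 nM, and a fair chance that only a limit is reported.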

Compound 4, half-maximal inhibitory concentration: 33300 nM
Compound 4: middle estimate off by 1.5-fold (0.18 log units), on the high side; measured number inside the range.
By their numbers in this assay, from the lowest: compounds 4, 1 and 2 (each within the scatter of the next). At a limit, above all of these: compound 3.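

On the phenyl ring carried by the nitrogen, hydroxy in place of fluoro gives a 1.5-fold lower number from compound 2 to compound 4 (0.17 log units; within the scatter), and hydroxy in place of hydrogen gives a 1.4-fold lower number from compound 1 to compound 4 (0.16 log units; within the scatter). For the compounds shown here, compound 4 is the first compound here with a hydrogen-bond donor in this group, and in this assay that change moves the number no further than the scatter allows. The swap from 2-bromophenyl to 3-hydroxyphenyl gives an at least 1.5-fold lower number from compound 3 to compound 4 (0.17 log units; that floor lies within the scatter), a floor only, and its full size cannot be read, since compound 3 holds a limit: the limit of > 50000 nM in this assay, at which 1 of the 4 values shown sits.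

On these data alone, it remains open whether an amine, a methoxy group or a carboxylic acid on this ring would give a step beyond the scatter. Going by these compounds alone, no readable step so far does so, which leaves the groups that could shift this number in this assay unidentified.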